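Pyridin-2-yl in place of ethyl: clearance of compound 3

The source may hold more compounds than are shown below. What is called first, only, known or untested is meant among the compounds shown, and "the series" means these compounds.

Values measured so far in an ADME assay (liver) for metabolic stability, with Liver microsome (Rattus norvegicus) as the target, using microsomes and NADPH, with a stated time of 30 min, at 37 degrees C, tested at 1 uM (a lower number here means slower removal, a higher number faster removal of the compound), are these
Compound 1 `Nc1ccc(S(=O)(=O)c2ccc(-c3ncc(C(O)(C(F)(F)F)C(F)(F)F)cn3)cc2)cn1` gives < 14 mL.min-1.g-1 (a limit of the assay, not a number)
Compound 2 `CCNc1nc(S(=O)(=O)c2ccc(N)nc2)ccc1-c1ccc(C(C)(O)C(F)(F)F)cn1` gives 42 mL.min-1.g-1 (a measured number)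

Going by the values given here, compound 2, at 42 mL.min-1.g-1 in this assay, holds the only true number in this small set. The one other result, that of compound 1, is a limit of the assay. Among the compounds with values here, nothing yet ranks compound 2 against a wider series, and no pair of measured compounds differs in one place alone.

The next compound is compound 3 `CC(O)(c1ccc(-c2ccc(S(=O)(=O)c3ccc(N)nc3)nc2Nc2ccccn2)nc1)C(F)(F)F`, which carries pyridin-2-yl in place of ethyl on a nitrogen on an aromatic ring, so that ethylamino becomes (pyridin-2-yl)amino: pyridin-2-yl in place of ethyl on a nitrogen on an aromatic ring. Within the data shown here, no measured step shows what this change does, so the expectation rests only on compound 2 at 42 mL.min-1.g-1 and on the change itself.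

The expected step is small, an estimated 1.3-fold lower number from compound 2 to compound 3 (0.12 log units; within the scatter), leaning slightly towards slower removal but not beyond the usual scatter of repeat measurements. For compound 3 the expected value is 32 mL.min-1.g-1 (estimated range 14 mL.min-1.g-1 to 75 mL.min-1.g-1).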

Compound 3, intrinsic clearance in microsomes: 130 mL.min-1.g-1
Estimate against measurement, compound 3: 4.1-fold (0.61 log units) below; measured number above the stated range.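

In this assay, going by these compounds alone, this is the first step that can be read between two compounds differing in one place: pyridin-2-yl in place of ethyl on a nitrogen on an aromatic ring gives a 3.1-fold higher number from compound 2 to compound 3 (0.49 log units; beyond the scatter). It shows that clearance in this assay responds to the group held on this nitrogen, and that this exchange of a small chain for a six-membered aromatic ring goes towards faster removal, not slower, on a step that lies beyond the usual scatter. Compound 1 remains a limit of the assay, not a number, and it adds no step to this comparison: the limit of < 14 mL.min-1.g-1 in this assay, at which 1 of the 3 values shown sits.

This single step cannot say whether the change follows from the ring as such, from its ring nitrogen or simply from the larger group, and nothing shown gives a cause for it. A phenyl on the same nitrogen would set the ring apart from its hetero atom, while a propyl or a longer chain would show how clearance runs with the chain alone.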